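Trimming a methyl from the pyrazole of compound 1

The source may report more compounds than this note shows. Statements on the series, on what has been measured and on what is new or still open speak of the compounds shown alone.

Measured so far:
compound 1, `CCCC(Oc1ccc(-n2cc(C(F)(F)F)c(C)n2)cc1)c1ccc(C(=O)NCCC(=O)O)cc1`: < 10 mL/min/kg
compound 2, `CCCC(Oc1ccc(-n2cc(F)cn2)cc1)c1ccc(C(=O)NCCC(=O)O)cc1`: 12 mL/min/kg

In an ADME assay on microsomes from liver (Homo sapiens) for metabolic stability (a lower number here means slower removal, a higher number faster removal of the compound), compound 1 returns only a limit, < 10 mL/min/kg, not a number. In this assay compound 2 gives 12 mL/min/kg. Among the measured compounds shown here, the one measured step, an at least 1.2-fold higher number from compound 1 to compound 2 (0.07 log units; that floor lies within the scatter), rests on that limit, as the limit of < 10 mL/min/kg in this assay, at which 1 of the 2 values shown sits, shows, and tells little about direction.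

Compound 3, `CCCC(Oc1ccc(-n2cc(C(F)(F)F)cn2)cc1)c1ccc(C(=O)NCCC(=O)O)cc1`, differs from compound 1 by hydrogen in place of methyl on an aromatic carbon. For the measured compounds named here, no measured pair shares this change; the step from compound 1 to compound 2 alters the same ring but swaps both substituents at once, so it bears only loosely on compound 3. With both measured values near the floor, no step beyond the scatter is expected for compound 3 in this assay. The expected change is a step that the limit leaves unreadable from compound 1 to compound 3, and the result may again come back as a limit. Compound 3 is estimated at 9 mL/min/kg, within 5 mL/min/kg to 18 mL/min/kg.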

Compound 3, clearance: 16 mL/min/kg
Beside the measured number, compound 3's estimate is 1.8-fold (0.25 log units) below it, within the range that was stated.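

Compound 3 separates the two changes that the step from compound 1 to compound 2 made at once: the trifluoromethyl group stays and only the methyl on the five-membered aromatic ring gives way to hydrogen, and in this assay this reads as an at least 1.6-fold higher number from compound 1 to compound 3 (0.20 log units; that floor lies within the scatter). The other half of that earlier double change can now be read on its own, with no methyl on either side, as a 1.3-fold higher number from compound 2 to compound 3 (0.12 log units; within the scatter), so this pair does not tell trifluoromethyl and fluoro apart in this assay. The value of compound 1 is a limit and not a number, so the step that removes the methyl gives only a floor and no size: the limit of < 10 mL/min/kg in this assay, at which 1 of the 3 values shown sits.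

From the compounds shown here alone, what the methyl contributes at this position therefore stays open, as any true size for that step would need a number for compound 1 rather than a limit. Also open, going by these compounds, is how this aromatic carbon next to the ring nitrogen would read with an ethyl group, a chlorine or a nitrile there, and whether the methyl would give the same step with fluoro in place of trifluoromethyl.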